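The source may report more compounds than this note shows. Statements on the series, on what has been measured and on what is new or still open speak of the compounds shown alone.

Compound 3 `COC1CC(C(=O)N2CCc3nc(C#Cc4ccccc4)sc3C2)C1` stands at the limit of an assay on HEK293 cells for negative allosteric modulation of metabotropic glutamate receptor 5 (Homo sapiens), read by FLIPR, with a stated time of 1 h; a higher number here means a weaker inhibitor, a lower number a stronger inhibitor: in this assay compound 3 gives > 10000 nM, a limit rather than a number. Compound 1 `C(#Cc1nc2c(s1)CN(C1CCCCC1)CC2)c1ccccc1` sits at the same limit, giving > 10000 nM in this assay. Compound 2 `O=C(C1CCC1)N1CCc2nc(C#Cc3ccccc3)sc2C1` gives 370 nM in this assay. Toward compound 4 `Cc1cccc(C(=O)N2CCc3nc(C#Cc4ccccc4)sc3C2)n1` the change is 6-methylpyridin-2-yl in place of 3-methoxycyclobutyl on a carbonyl carbon. For the measured compounds named here, no measured step makes this exchange; the nearest are an at least 27-fold lower number from compound 1 to compound 2 (1.43 log units; beyond the scatter) and an at least 27-fold higher number from compound 2 to compound 3 (1.43 log units; beyond the scatter), both large and both changing the group carried by the ring nitrogen, while the limit of > 10000 nM in this assay, at which 2 of the 3 values shown sit, leaves a step that the two limits leave unreadable from compound 1 to compound 3 unreadable. A lower number is therefore expected, with the step estimated as an at least 16-fold lower number from compound 3 to compound 4 (1.22 log units; beyond the scatter). Compound 4 is estimated at 600 nM, between 100 nM and 6000 nM.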

Compound 4, half-maximal inhibitory concentration: > 10000 nM
Compound 4 was reported as a limit (the forecaster's own chance of this, stated with the estimate: 30%); middle value at least 16-fold (1.22 log units) from the limit.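

In this assay, 6-methylpyridin-2-yl on the carbonyl carbon gives an at least 27-fold higher number from compound 2 to compound 4 (1.43 log units; beyond the scatter), so an aromatic ring there fares no better than 3-methoxycyclobutyl. Of the three groups shown on this carbonyl carbon, only cyclobutyl, in compound 2, gives a value short of the limit. The steps between compounds at the limit cannot be read: the limit of > 10000 nM in this assay, at which 3 of the 4 values shown sit.

From the compounds shown here alone, it remains open whether phenyl, pyridin-2-yl without the methyl, or cyclopropyl on this carbonyl carbon would give a value short of the limit.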